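This account rests on a few compounds, and the source may have more. Where it says the series, first, only, none or still open, it means among the compounds named here.

In a functional assay (muscle tissue) with Cavia porcellus as the target (on this read-out higher numbers stand for an effect only at larger amounts of compound and lower numbers for an effect already at smaller amounts), three compounds sharing one core have been measured. Compound 1 (`COC(=O)C1=C(C)N=C(C)/C(=C(\O)OC)C1c1cccc(OC)c1`) gives 191 nM, compound 2 (`COC(=O)C1=C(C)N=C(C)/C(=C(\O)OC)C1c1ccccc1Cl`) gives 2.19 nM, and compound 3 (`COC(=O)C1=C(C)N=C(C)/C(=C(\O)OC)C1c1ccccc1I`) gives 46.8 nM. Compound 3 therefore holds the second highest of the three numbers, lying well under compound 1 and well over compound 2.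

Compound 4 (`COC(=O)C1=C(C)N=C(C)/C(=C(\O)OC)C1c1cccc(Br)c1`) has 3-bromophenyl in place of 2-iodophenyl on a saturated ring carbon. Within the data shown here, three measured steps bear on this change, though none matches it directly. Among the measured compounds shown here, no measured compound carries bromo, and the only measured group numbered 3 is the 3-methoxyphenyl of compound 1. Swapping chloro for iodo alone gave a large step, a 21-fold higher number from compound 2 to compound 3 (1.33 log units; beyond the scatter). Replacing 3-methoxyphenyl gave a modest step with 2-iodophenyl, a 4.1-fold lower number from compound 1 to compound 3 (0.61 log units; beyond the scatter), and a large one with 2-chlorophenyl, an 87-fold lower number from compound 1 to compound 2 (1.94 log units; beyond the scatter). Halogen-bearing compound 2 and compound 3 thus both lie under compound 1, and bromo is expected to leave compound 4 under that number too. A small shift towards a lower number is therefore expected, with no clear move beyond the scatter, as the estimated 1.9-fold lower number from compound 3 to compound 4 (0.27 log units; within the scatter). For compound 4 the estimated value is 25 nM, with an expected range from 5 nM to 120 nM.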

Compound 4, half-maximal effective concentration: 1.29 nM
Beside the measured number, compound 4's estimate is 19-fold (1.29 log units) above it, outside the stated range (below it).
By their numbers in this assay, from the lowest: compounds 4 and 2 (each within the scatter of the next); then compound 3; then compound 1.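

In this assay, among these compounds, compound 4 shows that a group numbered 3 on this phenyl ring does not by itself bring a high number: bromo in place of methoxy gives a 150-fold lower number from compound 1 to compound 4 (2.17 log units; beyond the scatter) and so separates the result of compound 1 from the 3-substituted phenyl pattern as such. 3-Bromophenyl and 2-chlorophenyl cannot be told apart here, with a 1.7-fold lower number from compound 2 to compound 4 (0.23 log units; within the scatter) as their step, while the replacement of 2-iodophenyl by 3-bromophenyl gives a 36-fold lower number from compound 3 to compound 4 (1.56 log units; beyond the scatter) and leaves compound 3 as the only halogen-bearing compound with a clearly higher number. Nothing at hand gives a reason for any of these steps.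

Chloro, bromo and iodo each appear at only one ring position here, so the identity of the halogen and its position on the phenyl ring remain tied together, and 3-chlorophenyl, 3-iodophenyl or 2-bromophenyl would be needed to separate them. Going by these compounds, it also remains open whether a group of another kind at the position held by bromo, such as an amine, a nitro group or a carboxylic acid, would stay with compound 4 or move towards compound 1.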